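The source may report more compounds than this note shows. Statements on the series, on what has been measured and on what is new or still open speak of the compounds shown alone.

Compound 1 `COc1nc(-c2ccccc2F)ccc1[C@@H](c1ccccc1)[C@@](O)(CCN(C)C)c1cccc2ccccc12` opens the series in a toxicity assay on Vero cells (Chlorocebus sabaeus) for cytotoxicity; a lower number here means that less compound is tolerated, a higher number that more compound is tolerated. In this assay compound 1 gives > 50 ug/mL, which is a limit of the assay rather than a number. Compound 2 `COc1nc(-c2ccc(F)cc2)ccc1[C@@H](c1ccccc1)[C@@](O)(CCN(C)C)c1cccc2ccccc12` gives > 50 ug/mL in this assay, again a limit. Compound 3 `COc1nc(-c2ccccc2Cl)ccc1[C@@H](c1ccccc1)[C@@](O)(CCN(C)C)c1cccc2ccccc12` gives > 50 ug/mL in this assay, also a limit. The steps a step that the two limits leave unreadable from compound 1 to compound 2, a step that the two limits leave unreadable from compound 1 to compound 3 and a step that the two limits leave unreadable from compound 2 to compound 3 therefore cannot be sized, as the limit of > 50 ug/mL in this assay, at which 3 of the 3 values shown sit, shows. Compound 4 `COc1nc(-c2cnsc2)ccc1[C@@H](c1ccccc1)[C@@](O)(CCN(C)C)c1cccc2ccccc12` has not yet been measured; it differs from compound 1 by 1,2-thiazol-4-yl in place of 2-fluorophenyl on an aromatic carbon. Among the measured compounds shown here, none of the measured steps resembles this exchange, and none of them is readable, so no direction beyond the scatter can be drawn from them. Compound 4 is expected to give 55 ug/mL, within a range from 30 ug/mL to 100 ug/mL. The expected step that the limit leaves unreadable from compound 1 to compound 4 is thus estimated as none beyond the scatter.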

Compound 4, half-maximal cytotoxic concentration: 26.3 ug/mL
Beside the measured number, compound 4's estimate is 2.1-fold (0.32 log units) above it, and the stated range ends above it.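

In this assay, compound 4 is the only compound shown with a number rather than a limit, so swapping the aryl group at this position can now be sized from one side: an at least 1.9-fold lower number from compound 1 to compound 4 (0.27 log units; that floor lies within the scatter), an at least 1.9-fold lower number from compound 3 to compound 4 (0.27 log units; that floor lies within the scatter) and an at least 1.9-fold lower number from compound 2 to compound 4 (0.27 log units; that floor lies within the scatter). Each step is only a floor, so 1,2-thiazol-4-yl is not shown to be clearly less tolerated than the phenyl groups. The true size stays unknown because the other values are limits: the limit of > 50 ug/mL in this assay, at which 3 of the 4 values shown sit.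

Going by these compounds, it remains open whether ring size or the ring's nitrogen and sulfur atoms matter. A thienyl or pyridyl group here would help separate the two.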